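Naphthyl regioisomer swap on the shared core, compound 2 to 3

This account rests on a few compounds, and the source may have more. Where it says the series, first, only, none or still open, it means among the compounds named here.

Two compounds of the series carry a measurement in a functional assay on HeLa cells (Homo sapiens) for inhibition, read by CCK-8 assay, with a stated time of 48 h; on this read-out lower numbers stand for stronger inhibition and higher numbers for weaker inhibition. Compound 1 `Fc1ccc(C2=NN(C3=NC(c4ccccc4)CS3)C(c3ccc4ccccc4c3)C2)cc1` gives in this assay 9730 nM, and compound 2 `Cc1ccc(C2=NN(C3=NC(c4ccccc4)CS3)C(c3cccc4ccccc34)C2)cc1C` gives 1720 nM. Of the two numbers compound 2 stands lowest, with compound 1 as its nearest neighbour at a gap that lies beyond the usual scatter. Compound 1 and compound 2 differ in more than one place, so no single-change step can be read between them.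

Compound 3 `Cc1ccc(C2=NN(C3=NC(c4ccccc4)CS3)C(c3ccc4ccccc4c3)C2)cc1C` is not yet measured. It differs from compound 2 in one place: naphthalen-2-yl in place of naphthalen-1-yl on a saturated ring carbon. The same naphthalen-2-yl is present in compound 1, but compound 1 also carries a different aryl group, so its value cannot be taken as a reading of this change alone. Among the measured compounds shown here, no step for this change is known from measured pairs.

The expectation is a modest rise, towards weaker inhibition, not far beyond the scatter, with a 1.9-fold higher number from compound 2 to compound 3 (0.27 log units; within the scatter) as the expected step. Compound 3 is estimated at 3200 nM, in a range from 1200 nM to 9000 nM.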

Compound 3, half-maximal inhibitory concentration: 950 nM
For compound 3 the middle estimate is 3.4-fold (0.53 log units) above the measured one; measured number outside the range, below it.
By their numbers in this assay, from the lowest: compounds 3 and 2 (each within the scatter of the next); then compound 1.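

In this assay, naphthalen-2-yl in place of naphthalen-1-yl on the saturated ring carbon gives a 1.8-fold lower number from compound 2 to compound 3 (0.26 log units; within the scatter), so with the 3,4-dimethylphenyl group held fixed, the two naphthyl attachments cannot be told apart at this position. Among the compounds shown here, with naphthalen-2-yl held fixed, 3,4-dimethylphenyl in place of 4-fluorophenyl on the carbon with a double bond to nitrogen gives a 10-fold lower number from compound 1 to compound 3 (1.01 log units; beyond the scatter), the first single-change reading at this aryl position and the only step here beyond the scatter. Nothing available explains either step.

Still open, going by these compounds, is which part of the aryl change carries the large step, since a single methyl, as in 4-methylphenyl, or an unsubstituted phenyl would separate the contribution of the two methyl groups from the loss of fluorine. On these data alone, it is also open whether this position accepts an amine or a carboxylic acid on the aryl ring, and whether the naphthyl result holds when 4-fluorophenyl takes the place of 3,4-dimethylphenyl.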